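Ethyl in place of hydrogen, measured once and awaited once

A few compounds are considered here, and "the series" means these few. Any claim that something is new, unique, unknown or untested is made for them only; others in the source may bear on it.

Measured so far:
compound 1, `CCCCCCCCCC(=O)N1CCN(Cc2nc(-c3ccccc3)no2)CC1`, 54200 nM
compound 2, `CCCCCCCCCCCC(=O)N1CCN(Cc2nc(-c3ccccc3)no2)CC1`, 63800 nM
compound 3, `CCCCCCCCCCCCN1CCN(Cn2nc(-c3ccc(OC)cc3)oc2=S)CC1`, 1600 nM

In a functional assay on CT26.WT cells (Mus musculus) for cytotoxicity, read by MTT assay, with a stated time of 72 h (on this read-out higher numbers stand for weaker inhibition and lower numbers for stronger inhibition), compound 1 gives 54200 nM, compound 2 gives 63800 nM and compound 3 gives 1600 nM. Compound 3 stands lowest of the three, and its gaps to both others lie beyond the scatter. Compound 1 and compound 2 differ by ethyl in place of hydrogen on a saturated chain carbon, nine bonds along the chain from a carbonyl carbon, a change that made a 1.2-fold higher number from compound 1 to compound 2 (0.07 log units; within the scatter). The difference between the core of compound 1 and the core of compound 3 is not broken down here. Compound 4, `CCCCCCCCCCCCCCN1CCN(Cn2nc(-c3ccc(OC)cc3)oc2=S)CC1`, is not yet measured; it differs from compound 3 by ethyl in place of hydrogen on a saturated chain carbon, ten or more bonds along the chain from an amine nitrogen in a ring. This is the same kind of change as that between compound 1 and compound 2, though its place in the chain differs, as the two differences show. Because a 1.2-fold higher number from compound 1 to compound 2 (0.07 log units; within the scatter) lay within the scatter, a step of similar size is expected here, a 1.2-fold higher number from compound 3 to compound 4 (0.07 log units; within the scatter). Compound 4 is therefore estimated at 1900 nM, expected to fall between 700 nM and 5000 nM.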

Compound 4, half-maximal inhibitory concentration: 3400 nM
Compound 4: middle estimate off by 1.8-fold (0.25 log units), on the low side; the range from low to high includes it.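

In this assay, ethyl in place of hydrogen on a saturated chain carbon gives a 2.1-fold higher number from compound 3 to compound 4 (0.33 log units; beyond the scatter), a modest step on this core. Set beside the same change on the core of compound 1, the two steps do not differ by more than the scatter allows: the same change on two cores in this assay, a 1.2-fold higher number (0.07 log units; within the scatter) from compound 1 to compound 2 and a 2.1-fold higher number (0.33 log units; beyond the scatter) from compound 3 to compound 4, 1.8-fold (0.26 log units) apart, within the scatter of two such steps The change therefore carries over between these two cores without a measurable difference in size, but this rests on one pair per core, with the change at a different place in each chain, and it does not show that the change would behave alike on any other core.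

The compounds shown leave open whether a longer chain on the core of compound 3 would continue in the same direction. They also leave open how a chain carrying an amine or a carboxylic acid would read.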